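Swapping a Ketone for its Oxime Relative

The compounds below may be only part of what the source reports. "The series", "measured", "known", "first", "only" and "open" are said of these compounds alone.

Measured compounds:
compound 1 `COc1ccc(-c2nnc(SC/C(=N/O)c3ccccc3)n2-c2ccccc2)cc1` gives 63%
compound 2 `O/N=C(/CSc1nnc(-c2ccccc2)n1-c1ccccc1)c1ccccc1` gives 63%
compound 3 `CCn1c(SCC(=O)c2ccccc2)nnc1-c1cc(OC)c(OC)c(OC)c1` gives 41%

In a functional assay on the whole organism (strain albino) for inhibition, with Rattus norvegicus as the target, read by paw edema, with a stated time of 2 h, at a dose of 0.28 mmol/kg by the oral route (on this read-out lower numbers stand for less inhibition and higher numbers for more inhibition at the one dose given (going by the name of the read-out)), compound 3 stands lowest of the three, and its gap to compound 1 and to compound 2 lies beyond the scatter in each case. Among the measured compounds shown here, the one measured step, no change at the digits printed from compound 1 to compound 2 (within the scatter), concerns a change on the core and gives no information about the part of the molecule that is altered here.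

Compound 4 `CCn1c(SC/C(=N/O)c2ccccc2)nnc1-c1cc(OC)c(OC)c(OC)c1` differs from compound 3 in one place: a group of 9 heavy atoms (7 carbon, 1 nitrogen, 1 oxygen; one six-membered aromatic ring of carbon only) in place of a group of 8 heavy atoms (7 carbon, 1 oxygen; one six-membered aromatic ring of carbon only), on a saturated chain carbon bound to a sulfur. For the measured compounds named here, compounds 1 and 2 both carry this entering group on a chain carbon bound to a sulfur, and both sit higher in this assay than compound 3, which carries the benzoyl; but they also differ from compound 3 in the substituents on the core, so no measured step isolates the benzoyl-to-entering-group exchange itself. On that evidence an upward move is expected, but with wide uncertainty. Compound 4 is estimated at 54%, within a range from 42% to 66%. This expectation corresponds to an estimated step of a number 13 percentage points higher from compound 3 to compound 4 (beyond the scatter) in the upward direction.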

Compound 4, a percentage reported as inhibition, in the whole organism at one dose (the size of the read-out at that dose, not a potency): 67%
Beside the measured number, compound 4's estimate is 13 percentage points below it; the measured number lies above the stated range.
By their numbers in this assay, from the lowest: compound 3; then compounds 1, 2 and 4 (each within the scatter of the next).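

With the shared core held fixed, the exchange of the benzoyl for the oxime-bearing group on the saturated chain carbon bound to a sulfur moves the result in this assay by a number 26 percentage points higher from compound 3 to compound 4 (beyond the scatter) in this one matched pair. Among the compounds shown here, this is the first direct reading of the change itself, as the earlier compounds with this group all differed from compound 3 on the core as well. The entering group carries a hydrogen-bond donor that the benzoyl lacks, but no measurement here ties the rise to that difference or to any other feature of the group.

A methoxy group on the oxime nitrogen, or a simple hydroxyl or an amine on that chain carbon in place of the carbonyl, would help show which part of the oxime goes with the higher number, but the compounds shown include none of these. On these data alone, whether the same exchange gives a similar rise on other cores also stays open, since compound 1 and compound 2 have no benzoyl partner here, and a single dose at a single time says nothing about potency.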